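The compounds below may be only part of what the source reports. "The series", "measured", "known", "first", "only" and "open" are said of these compounds alone.

In an in vitro ADME assay on microsomes from liver (Homo sapiens) for metabolic stability, tested at 1 uM (a lower number here means that the compound disappears faster, a higher number that the compound lasts longer), compound 3 `CC(C)(O)CCN1CCC(NS(=O)(=O)c2cc(S(=O)(=O)c3ccccc3)ccc2C(F)(F)F)CC1` gives < 0.0167 h, which is a limit of the assay and not a number. Compound 3 therefore stands at the limit of < 0.0167 h in this assay, at which 1 of the 3 values shown sits. Compound 1 `O=C(c1cccnc1)N1CCC(NS(=O)(=O)c2cc(S(=O)(=O)c3ccccc3)ccc2C(F)(F)F)CC1`, with (pyridin-3-yl)carbonyl on the amine nitrogen in the ring, gives 0.1 h. Compound 2 `O=C(O)c1cccc(S(=O)(=O)N2CCC(NS(=O)(=O)c3cc(S(=O)(=O)c4ccccc4)ccc3C(F)(F)F)CC2)c1`, with (3-carboxyphenyl)sulfonyl there, gives > 0.5 h, again a limit of the assay.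

Compound 4 `O=C([C@H]1CCNC1)N1CCC(NS(=O)(=O)c2cc(S(=O)(=O)c3ccccc3)ccc2C(F)(F)F)CC1` has (pyrrolidin-3-yl)carbonyl in place of 3-hydroxy-3-methylbutyl on that nitrogen: (pyrrolidin-3-yl)carbonyl in place of 3-hydroxy-3-methylbutyl on an amine nitrogen in a ring. For the measured compounds named here, two measured steps bear on this change, as both bring in 3-hydroxy-3-methylbutyl at the same place. One is modest at the least, an at least 5.9-fold lower number from compound 1 to compound 3 (0.77 log units; beyond the scatter), and the other is large, an at least 29-fold lower number from compound 2 to compound 3 (1.47 log units; beyond the scatter).

Compound 4 keeps a carbonyl on the nitrogen, as does compound 1 at 0.1 h, so the first step, read backwards, is the closer guide. In this assay, a rise beyond the scatter is expected, with an estimated at least 5.9-fold higher number from compound 3 to compound 4 (0.77 log units; beyond the scatter). For compound 4, the estimate is 0.1 h, with an expected range from 0.03 h to 0.4 h.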

Compound 4, half-life: > 0.5 h
Compound 4: only a limit was reported (the forecaster's own chance of this, stated with the estimate: 20%); at least 5.0-fold (0.69 log units) between middle value and limit.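

The carbonyl alone does not set the result in this assay: pyrrolidin-3-yl in place of pyridin-3-yl on the carbonyl carbon gives an at least 5.0-fold higher number from compound 1 to compound 4 (0.69 log units; beyond the scatter). On the amine nitrogen in the ring, (pyrrolidin-3-yl)carbonyl in place of 3-hydroxy-3-methylbutyl gives an at least 29-fold higher number from compound 3 to compound 4 (1.47 log units; beyond the scatter), and both ends of that step are limits of the assay. Compound 4 gives a limit of the assay while carrying no (3-carboxyphenyl)sulfonyl group, so that group is not needed to reach it: the limit of > 0.5 h in this assay, at which 2 of the 4 values shown sit.

From the compounds shown here alone, the step from compound 2 to compound 4 cannot be read, as both values are limits, so the order of these two stays unknown. Also open, going by these compounds, is whether the ring nitrogen of the pyrrolidine matters, which a cyclopentyl on the carbonyl carbon would test, and whether the opposite stereocentre gives the same result.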